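Pyrimidinyl for methoxyphenyl on the piperazine of compound 3

The source may hold more compounds than are shown below. What is called first, only, known or untested is meant among the compounds shown, and "the series" means these compounds.

Compound 3 `CCO/N=C(\CCN1CCN(c2cccc(OC)c2)CC1)c1ccccc1` gives 2680 nM in a functional assay on HEK293 cells with D(4) dopamine receptor (Homo sapiens) as the target, read by FLIPR (a higher number here means that more compound is needed for the effect, a lower number that less compound is needed), the highest of the three numbers; compound 1 `Cc1ccccc1/C(CCN1CCN(c2ccccn2)CC1)=N/O` gives 4.2 nM and compound 2 `Cc1cccc(/C(CCN2CCN(c3ccccn3)CC2)=N/O)c1` gives 2.3 nM. Compound 4 `CCO/N=C(\CCN1CCN(c2ncccn2)CC1)c1ccccc1` differs from compound 3 by pyrimidin-2-yl in place of 3-methoxyphenyl on an amine nitrogen in a ring. For the measured compounds named here, the only step between measured compounds, a 1.8-fold lower number from compound 1 to compound 2 (0.26 log units; within the scatter), concerns the methylphenyl on the oxime carbon and does not bear on the piperazine substituent. Compounds 1 and 2 carry a pyridinyl on that nitrogen together with an unsubstituted oxime, whereas compound 3 carries a methoxyphenyl with an ethyl oxime ether, so the two differences cannot be separated. For compound 4 a lower number than compound 3 is expected, a step of a 5.4-fold lower number from compound 3 to compound 4 (0.73 log units; beyond the scatter), with wide uncertainty. The estimate for compound 4 is 500 nM, range 80 nM to 3000 nM.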

Compound 4, half-maximal effective concentration: 615 nM
Estimate against measurement, compound 4: 1.2-fold (0.09 log units) below; the range from low to high includes it.
By their numbers in this assay, from the lowest: compounds 2 and 1 (each within the scatter of the next); then compound 4; then compound 3.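

With the ethyl oxime ether and the rest of the core held constant, the group on the amine nitrogen in a ring can now be read on its own in this assay: the change gives a 4.4-fold lower number from compound 3 to compound 4 (0.64 log units; beyond the scatter) and is a modest step. This position therefore accepts a six-membered aromatic ring with 2 hetero atoms in place of one of carbon only. Nothing measured accounts for the step.

No pair shown isolates the ethyl on the oxime oxygen from the unsubstituted oxime. On these data alone, how an unsubstituted phenyl or a pyrimidin-5-yl on that nitrogen would read also remains open.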